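The compounds below may be only part of what the source reports. "The series", "measured", "known", "first", "only" and "open" are said of these compounds alone.

The measured compounds in a functional assay on the whole organism (Abdomen) with Mus musculus as the target; a lower number here means that less compound is needed, a higher number that more compound is needed for the effect:
- compound 1, `CCc1sc(C)nc1Cc1c[nH]cn1`: 2.3 mg/kg
- compound 2, `CCc1sc(C(C)C)nc1Cc1c[nH]cn1`: 7.5 mg/kg
- compound 3, `CCc1nc(Cc2c[nH]cn2)c(C)s1`: only a limit of the assay, > 30 mg/kg

Compounds 1 and 3 are built from the same atoms joined differently; the difference between the two cores is not broken down here. Going from compound 1 to compound 2 means (isopropyl in place of methyl on an aromatic carbon), and it gave a 3.3-fold higher number from compound 1 to compound 2 (0.51 log units; beyond the scatter). Compound 4, `CCc1nc(Cc2c[nH]cn2)c(C(C)C)s1`, is not yet measured; it arises from compound 3 by the same kind of change, (isopropyl in place of methyl on an aromatic carbon), although here the carbon that changes sits next to the ring sulfur and next to the ring atom that bears a group of 6 heavy atoms, two ring bonds from the ring nitrogen, rather than next to the ring nitrogen. Compound 3 already sits at the limit of > 30 mg/kg in this assay, at which 1 of the 3 values shown sits. Compound 4 is expected to need a still higher dose, a step that the limit leaves unreadable from compound 3 to compound 4 in this assay, resting on a 3.3-fold higher number from compound 1 to compound 2 (0.51 log units; beyond the scatter). The estimate for compound 4 is 80 mg/kg, between 30 mg/kg and 250 mg/kg, and most probably the assay will again report only a limit.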

Compound 4, dose for half-maximal effect: 25.3 mg/kg
For compound 4 the middle estimate is 3.2-fold (0.50 log units) above the measured one; measured number outside the range, below it.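

In this assay, the change from methyl to isopropyl did not carry over in the same way from one core to the other: the same change on two cores in this assay, a 3.3-fold higher number (0.51 log units; beyond the scatter) from compound 1 to compound 2 and an at least 1.1-fold lower number (0.07 log units; that floor lies within the scatter) from compound 3 to compound 4, at least 3.8-fold (0.58 log units) apart, beyond the scatter of two such steps

On the core of compound 3, the change gave an at least 1.1-fold lower number from compound 3 to compound 4 (0.07 log units; that floor lies within the scatter), so the higher number seen on the core of compound 1 did not recur. Compound 3 has only a limit of the assay, > 30 mg/kg, so the full size of this step remains unread, and two pairs set no rule for other cores or groups.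

The compounds shown leave open how a longer chain, such as butyl, or an amine would behave in place of the isopropyl on either core. They also leave open what a propyl chain in place of the ethyl group would do.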